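The compounds below may be only part of what the source reports. "The series", "measured", "known", "first", "only" and "open" are said of these compounds alone.

Values in a functional assay for inhibition, read by spectrophotometry, with a stated time of 10 min; a higher number here means that more compound is needed for the effect, a lower number that less compound is needed:
- compound 1 `CCOC(=O)COc1cc(O)c2c(=O)c(O)c(-c3ccc4c(c3)OC(c3ccc(OCC(=O)OCC)c(OC)c3)C(CO)O4)oc2c1`: 116000 nM
- compound 2 `C=CCCOc1cc(O)c2c(=O)c(O)c(-c3ccc4c(c3)OC(c3ccc(OCCC=C)c(OC)c3)C(CO)O4)oc2c1`: 145000 nM
- compound 3 `CCN(CC)C(=O)COc1cc(O)c2c(=O)c(O)c(-c3ccc4c(c3)OC(c3ccc(OCC(=O)N(CC)CC)c(OC)c3)C(CO)O4)oc2c1`: 59900 nM

Compound 3 and compound 1 lie within the scatter of each other. Compound 2 lies beyond the scatter of compound 3, with the higher number. Among the measured compounds shown here, no two measured compounds differ in only one place, so no single change can be read directly from these values.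

The next step runs from compound 3 to compound 4 `CCN(CC)C(=O)COc1cc(O)c2c(=O)c(O)c(-c3ccc4c(c3)OC(c3ccc(O)c(OC)c3)C(CO)O4)oc2c1`, which has hydrogen in place of (diethylcarbamoyl)methyl on an oxygen on an aromatic ring. For the measured compounds named here, none of the measured compounds has hydrogen on this oxygen, so the series offers only indirect guidance. Among the measured compounds, the number ranges only from compound 3 at 59900 nM to compound 2 at 145000 nM, despite different groups on the oxygens. On that basis, a small step in this assay toward a lower number is expected, possibly none beyond the scatter. The range is kept wide, as this change has not been tested in the series. The estimate for compound 4 is 38000 nM, with an expected range of 12000 nM to 120000 nM. This estimate means an expected step of a 1.6-fold lower number from compound 3 to compound 4 (0.20 log units; within the scatter).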

Compound 4, half-maximal effective concentration: 113000 nM
Estimate against measurement, compound 4: 3.0-fold (0.47 log units) below; low and high end bracket the measured number.
By their numbers in this assay, from the lowest: compounds 3, 4, 1 and 2 (each within the scatter of the next, the first and the last beyond it).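

In this assay, among the compounds shown here, going from (diethylcarbamoyl)methoxy to hydroxy on this oxygen gives a 1.9-fold higher number from compound 3 to compound 4 (0.28 log units; within the scatter) and is the first comparison that differs in only one place. The whole (diethylcarbamoyl)methyl group can therefore leave this oxygen without a step beyond the scatter. In this pair, that group is not shown to be needed for the read-out, and a free hydroxy at this place reads level with the amide-bearing chain within the scatter. Nothing measured on these compounds bears on why the pair reads this way.

On these data alone, compound 4 still carries (diethylcarbamoyl)methyl on its other substituted oxygen, so the effect of hydrogen at that second place remains open, as does whether the two places behave alike. As far as these compounds go, it also remains open whether a small methyl group, a chain ending in a primary amine or a carboxymethyl group bearing a carboxylic acid on this oxygen would give a step beyond the scatter from the hydroxy of compound 4.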